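The source may hold more compounds than are shown below. What is called first, only, known or untested is meant among the compounds shown, and "the series" means these compounds.

Compound 1 `CCNC(=O)Oc1ccc(Cl)cc1C(=O)Nc1ccc(Cl)cc1`, compound 2 `CCCNC(=O)Oc1ccc(Cl)cc1C(=O)Nc1ccc(Cl)cc1` and compound 3 `CCCCCCCCCNC(=O)Oc1ccc(Cl)cc1C(=O)Nc1ccc(Cl)c(Cl)c1` share a common core and were all tested in an ADME assay for metabolic stability, read by HPLC, at pH 7.4; on this read-out higher numbers stand for a longer-lived compound and lower numbers for a shorter-lived compound. In this assay compound 1 gives 43 h, compound 2 gives 43 h and compound 3 gives 43 h. The change methyl in place of hydrogen on a saturated chain carbon, two bonds along the chain from an amide-type nitrogen produced no change at the digits printed from compound 1 to compound 2 (within the scatter). Compound 4 `CCCCCCCCCCNC(=O)Oc1ccc(Cl)cc1C(=O)Nc1ccc(Cl)c(Cl)c1` has not yet been measured; it differs from compound 3 by methyl in place of hydrogen on a saturated chain carbon, nine bonds along the chain from an amide-type nitrogen. Going by the values given here, this is the same kind of change as the one made between compound 1 and compound 2, but not the same: the earlier one sits two bonds along the chain from an amide-type nitrogen, the new one nine bonds along. How the core of compound 3 differs from the core of compound 1 is not broken down here. Because that kind of change gave no change at the digits printed from compound 1 to compound 2 (within the scatter), the step is expected to be no change at the digits printed from compound 3 to compound 4 (within the scatter). Compound 4 is therefore estimated at 43 h, probably between 25 h and 75 h.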

Compound 4, half-life: 43 h
Compound 4: middle estimate and measured number agree at the digits printed; the measured number falls inside the stated range.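

In this assay, methyl in place of hydrogen on the chain of compound 3 gave no change at the digits printed from compound 3 to compound 4 (within the scatter). Set beside the earlier step, the change carries over between these two cores with the same result: the same change on two cores in this assay, no change at the digits printed (within the scatter) from compound 1 to compound 2 and no change at the digits printed (within the scatter) from compound 3 to compound 4, 1.0-fold (0.00 log units) apart, within the scatter of two such steps

Going by these compounds alone, this does not show that the change would read the same on every core, since only two cores are compared, and the methyl sits two bonds along the chain from an amide-type nitrogen in one step and nine bonds along in the other.

The compounds shown leave open how this assay would read for a longer chain, a branched chain, or a chain ending in an amine or a carboxylic acid.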